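The source may report more compounds than this note shows. Statements on the series, on what has been measured and on what is new or still open speak of the compounds shown alone.

Measured in an ADME assay on HepG2 cells (Homo sapiens) for cytotoxicity; on this read-out higher numbers stand for lower toxicity in this test and lower numbers for higher toxicity in this test:
compound 1 `CSc1cccc(N(C(=O)c2cc3ccc(C(F)(F)F)cc3[nH]2)[C@@H](C)C(=O)NC2CCCC2)c1`: 7100 nM
compound 2 `CSc1cccc(N2C(=O)CN(c3ccc(C(F)(F)F)cc3)CC2C(=O)NC2CCCC2)c1`: 10000 nM
compound 3 `COc1cccc(N2CC(=O)N(c3cccc(SC)c3)C(C(=O)NC3CCCC3)C2)c1`: > 50000 nM (a limit of the assay, not a number)

Compound 3 stands on a limit rather than a number: > 50000 nM. The top of the range shown is the limit of > 50000 nM in this assay, at which 1 of the 3 values shown sits. Compound 1 and compound 2 both gave numbers.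

The next change leads to compound 4 `CSc1cccc(N2C(=O)CN(c3cccnc3)CC2C(=O)NC2CCCC2)c1`, which has pyridin-3-yl in place of 3-methoxyphenyl on an amine nitrogen in a ring.

Within the data shown here, one measured step bears on this place: an at least 5.0-fold higher number from compound 2 to compound 3 (0.69 log units; beyond the scatter), with 3-methoxyphenyl replacing 4-(trifluoromethyl)phenyl on that same nitrogen. From the compounds shown here alone, it lies beyond the scatter, but its upper end is a limit, so its true size stays open. Among the measured compounds shown here, no measured compound carries pyridin-3-yl, and compound 1 offers no step at this place. The expectation therefore rests on this single step and stays loose.

The expected change is an at least 1.3-fold lower number from compound 3 to compound 4 (0.11 log units; that floor lies within the scatter), toward lower numbers if anything and not clearly beyond the scatter. A second reading at the limit is almost as likely as a number. For compound 4 the estimated value is 38000 nM, with an expected range of 14000 nM to 70000 nM.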

Compound 4, half-maximal cytotoxic concentration: > 50000 nM
Compound 4: no number, only a limit (the forecaster's own chance of this, stated with the estimate: 45%); middle value at least 1.3-fold (0.11 log units) from the limit.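

In this assay compound 4 gives > 50000 nM, which is a limit of the assay and not a number. Pyridin-3-yl in place of 4-(trifluoromethyl)phenyl on the amine nitrogen in the ring gives an at least 5.0-fold higher number from compound 2 to compound 4 (0.69 log units; beyond the scatter), so a second group at this nitrogen now leaves the numbers of compound 2 behind, and a ring with a hetero atom serves here as well as the all-carbon ring of 3-methoxyphenyl. Of the three groups shown on this nitrogen, only 4-(trifluoromethyl)phenyl, in compound 2, yields a number, while the step between the other two cannot be read, with both values resting on the same ceiling: the limit of > 50000 nM in this assay, at which 2 of the 4 values shown sit.

From the compounds shown here alone, how far compound 3 and compound 4 actually lie from each other stays open, as does any ranking of 3-methoxyphenyl against pyridin-3-yl, since neither has a number in this read-out. Also open, going by these compounds, is whether an unsubstituted phenyl on this nitrogen would stay at the limit or return to a number, which would show whether the trifluoromethyl group or the ring as a whole tracks with the lower value of compound 2.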